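Chloro Gives Way to Acetyl on a Shared Core

A few compounds are considered here, and "the series" means these few. Any claim that something is new, unique, unknown or untested is made for them only; others in the source may bear on it.

Compound 1 `O=C(CCC(=O)c1ccccc1)Nc1nc2ccc(Cl)cc2s1` and compound 2 `O=C(Nc1nc2ccc(Cl)cc2s1)c1ccccc1C(=O)c1ccccc1` share one core and differ only in the acyl part of the amide. In a functional assay on the whole organism with Mus musculus as the target, with a stated time of 4 h (on this read-out lower numbers stand for an effect already at smaller amounts and higher numbers for an effect only at larger amounts of compound), compound 1 gives 300 mg/kg. In this assay compound 2 gives 300 mg/kg, which stands level with compound 1 within the scatter of the method. Compound 3 `CC(=O)c1ccc2nc(NC(=O)c3ccccc3C(=O)c3ccccc3)sc2c1` has not yet been tested; it differs from compound 2 by acetyl in place of chloro on an aromatic carbon. Among the compounds with values here, with no measured step of this kind to lean on, one expects a step from compound 2 to compound 3 of no change at the digits printed from compound 2 to compound 3 (within the scatter), that is, nothing beyond the scatter in either direction. Compound 3 is therefore estimated at 300 mg/kg, with a range from 150 mg/kg to 600 mg/kg.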

Compound 3, minimum effective dose: 300 mg/kg
Compound 3: middle estimate and measured number agree at the digits printed; low and high end bracket the measured number.
By their numbers in this assay, from the lowest: compounds 1, 2 and 3 (each within the scatter of the next).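

In this assay, acetyl in place of chloro on an aromatic carbon gives no change at the digits printed from compound 2 to compound 3 (within the scatter) and so the read-out at this position stays within the scatter when three heavy atoms replace one. Compound 1 and compound 2 both carry chloro here and differ only in the acyl part, so they gave no reading of this position. No measured evidence bears on this result. From the compounds shown here alone, what an amine or a carboxylic acid at this position would give remains open, as does acetyl paired with the acyl part of compound 1.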